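A few compounds are considered here, and "the series" means these few. Any claim that something is new, unique, unknown or untested is made for them only; others in the source may bear on it.

Measured in a functional assay on SW-620 cells (Homo sapiens) for inhibition, read by MTT assay, with a stated time of 72 h; a lower number here means a stronger inhibitor, a higher number a weaker inhibitor:
- compound 1 `CNCc1c(OC)cc(Oc2cccc(Nc3ccccc3)c2)cc1OC`: 15000 nM
- compound 2 `COc1cc(Oc2cccc(Nc3ccccc3)c2)cc(OC)c1CNCc1ccc(C)cc1`: 11800 nM
- compound 3 `COc1ccc(CCCNCc2c(OC)cc(Oc3cccc(Nc4ccccc4)c3)cc2OC)cc1`: 6400 nM

The standing of compound 3 rests on one step beyond the scatter, a 2.3-fold lower number from compound 1 to compound 3 (0.37 log units; beyond the scatter), and one within it, a 1.8-fold lower number from compound 2 to compound 3 (0.27 log units; within the scatter). The remaining step, a 1.3-fold lower number from compound 1 to compound 2 (0.10 log units; within the scatter), is also within the scatter, so the measured range is narrow.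

The next change leads to compound 4 `COc1cc(Oc2cccc(Nc3ccccc3)c2)cc(OC)c1CNC(C)C`, with isopropyl in place of 3-(4-methoxyphenyl)propyl on an amine nitrogen. Within the data shown here, no measured step makes exactly this change. The closest guide is a 2.3-fold lower number from compound 1 to compound 3 (0.37 log units; beyond the scatter), since compound 1 also lacks the 4-methoxyphenyl group, and that step read in reverse points to a modest rise. A step of similar size towards a higher number is therefore expected in this assay. The estimated change is a 2.0-fold higher number from compound 3 to compound 4 (0.31 log units; beyond the scatter). For compound 4 the estimate is 13000 nM, with an expected range of 7000 nM to 25000 nM.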

Compound 4, half-maximal inhibitory concentration: > 20000 nM
Compound 4: only a limit was reported (the forecaster's own chance of this, stated with the estimate: 5%); middle value at least 1.5-fold (0.18 log units) away from the limit.
By their numbers in this assay, from the lowest: compounds 3, 2 and 1 (each within the scatter of the next, the first and the last beyond it). At a limit, above all of these: compound 4.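

In this assay compound 4 is reported only as a limit: the limit of > 20000 nM in this assay, at which 1 of the 4 values shown sits.
Among these compounds, replacing 3-(4-methoxyphenyl)propyl with isopropyl on the amine nitrogen gives an at least 3.1-fold higher number from compound 3 to compound 4 (0.49 log units; beyond the scatter) and so shows that this position responds to this exchange beyond the scatter, which the narrow spread of the earlier compounds did not establish. The other two comparisons give an at least 1.6-fold higher number from compound 2 to compound 4 (0.22 log units; that floor lies within the scatter) and an at least 1.3-fold higher number from compound 1 to compound 4 (0.12 log units; that floor lies within the scatter) and cannot rank isopropyl against 4-methylbenzyl or methyl, as both floors lie within the scatter.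

Going by these compounds, it remains open whether the difference between compound 3 and compound 4 follows the 4-methoxyphenyl ring or the chain itself, a question that a plain propyl chain on the same nitrogen, or a longer chain ending in an amine or a carboxylic acid, could address. On these data alone, how far the true value of compound 4 lies past its limit also remains open.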